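Fluoroindole positional swap on a hydroxamate series

The source may report more compounds than this note shows. Statements on the series, on what has been measured and on what is new or still open speak of the compounds shown alone.

Compound 1 `O=C(COc1ccc(CN2CC=C(c3c[nH]c4cccc(F)c34)CC2)c(F)c1)NO` and compound 2 `O=C(COc1ccc(CN2CC=C(c3c[nH]c4ccc(F)cc34)CC2)c(F)c1)NO` share a core and differ only in the fluoroindole. In a functional assay on HCT-116 cells (Homo sapiens) for antiproliferative activity, with a stated time of 72 h (on this read-out higher numbers stand for weaker inhibition and lower numbers for stronger inhibition), compound 1 gives 1220 nM. Compound 2 reaches only the limit of this assay, > 5000 nM. The change from compound 2 to compound 1 is 4-fluoro-1H-indol-3-yl in place of 5-fluoro-1H-indol-3-yl on a double-bonded ring carbon, and it gives an at least 4.0-fold lower number from compound 2 to compound 1 (0.61 log units; beyond the scatter); the step is stated as a bound because compound 2 sits at the limit (the limit of > 5000 nM in this assay, at which 2 of the 3 values shown sit).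

Compound 3 `O=C(COc1ccc(C(=O)N2CC=C(c3c[nH]c4ccc(F)cc34)CC2)cc1)NO` carries a different core, and the difference between its core and that of compound 2 is not broken down here. Compound 3 also reaches only the limit of this assay, > 5000 nM. Compound 4 `O=C(COc1ccc(C(=O)N2CC=C(c3c[nH]c4cccc(F)c34)CC2)cc1)NO` is not yet measured and differs from compound 3 by 4-fluoro-1H-indol-3-yl in place of 5-fluoro-1H-indol-3-yl on a double-bonded ring carbon, the same change as from compound 2 to compound 1, at the same place.

For compound 4 the step from compound 3 is expected to be an at least 1.6-fold lower number from compound 3 to compound 4 (0.22 log units; that floor lies within the scatter), set beside the measured step from compound 2 to compound 1, resting on that single pair and on compound 3 being at the limit (the limit of > 5000 nM in this assay, at which 2 of the 3 values shown sit). As far as these compounds go, how far the change carries over onto the core of compound 3 is unknown, so a limit remains quite possible. The estimate for compound 4 in this assay is 3000 nM, between 800 nM and 10000 nM.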

Compound 4, half-maximal inhibitory concentration: 1410 nM
Compound 4: the middle estimate sits 2.1-fold (0.33 log units) above what was measured; the measured number falls inside the stated range.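

On the second core, 4-fluoro-1H-indol-3-yl in place of 5-fluoro-1H-indol-3-yl in this assay gives an at least 3.5-fold lower number from compound 3 to compound 4 (0.54 log units; beyond the scatter), so a lower number with this change is no longer confined to the first core. Both steps point the same way and both lie beyond the scatter, which shows that the direction of the change carries over between these two cores: the same change on two cores in this assay, an at least 4.0-fold lower number (0.61 log units; beyond the scatter) from compound 2 to compound 1 and an at least 3.5-fold lower number (0.54 log units; beyond the scatter) from compound 3 to compound 4; the limit leaves it open whether they differ Neither step has a known full size, and the two pairs do not establish a rule for the wider series, because compound 2 and compound 3 each stand at a limit rather than at a number: the limit of > 5000 nM in this assay, at which 2 of the 4 values shown sit.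

The two cores differ in more than one place and that difference is not broken down, so the compounds shown leave open which part of the core, if any, affects the number or the size of the fluoroindole step. Also open, as far as these compounds go, is whether the step would persist with chlorine or a nitrile in place of the fluorine of 4-fluoro-1H-indol-3-yl, or with a carboxylic acid in place of the hydroxamate on either core.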